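The compounds below may be only part of what the source reports. "The series", "measured", "known", "first", "only" and "open" are said of these compounds alone.

Working notes on the triazene series in a functional assay on HeLa cells (Homo sapiens) for cytotoxicity, read by MTT assay, with a stated time of 72 h; on this read-out higher numbers stand for weaker inhibition and lower numbers for stronger inhibition.

Of the compounds shown here, three have numbers so far. Compound 1 `FC(F)(F)c1cc(/N=N/Nc2ccc(Cl)c(C(F)(F)F)c2)ccc1Cl` gives 58400 nM in this assay. Compound 2 `CC(=O)N(/N=N/c1ccc([N+](=O)[O-])cc1Br)c1ccc([N+](=O)[O-])cc1Br` gives 550 nM. Compound 3 `O=C(c1ccccc1C(F)(F)F)N(/N=N/c1ccc([N+](=O)[O-])cc1Cl)c1ccc([N+](=O)[O-])cc1Cl` gives 10600 nM; this is the second highest of the three numbers, with compound 1 the nearest neighbour at a higher number and compound 2 the furthest at a lower one, both gaps beyond the scatter. Within the data shown here, no pair among the measured compounds differs in only one place, so no single step is available for direct comparison.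

Compound 4 `COC(=O)N(/N=N/c1ccc([N+](=O)[O-])cc1Cl)c1ccc([N+](=O)[O-])cc1Cl` is the next to be measured. Against compound 3 the change is methoxy in place of 2-(trifluoromethyl)phenyl on a carbonyl carbon, the rest of the structure unchanged. Among the measured compounds shown here, the only reference for a change of the acyl part is the pair of compound 2 and compound 3, which also differ in their halogens; their two values show the acetyl compound far lower than the benzoyl compound. On that basis a downward step is expected for compound 4, of a size beyond the scatter, a 4.2-fold lower number from compound 3 to compound 4 (0.63 log units; beyond the scatter). The estimate for compound 4 is 2500 nM, with a range from 600 nM to 10000 nM.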

Compound 4, half-maximal inhibitory concentration: 980 nM
Estimate against measurement, compound 4: 2.6-fold (0.41 log units) above; the measured number falls inside the stated range.
By their numbers in this assay, from the lowest: compounds 2 and 4 (each within the scatter of the next); then compound 3; then compound 1.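

In this assay, the change on a carbonyl carbon whose other neighbour is the amide-type nitrogen can now be read as a single step, with an 11-fold lower number from compound 3 to compound 4 (1.03 log units; beyond the scatter) and the rest of the structure unchanged. The earlier compounds shown here touched this place only through compound 2 and compound 3, a pair that also differs in its halogens, whereas this step shows that the group on the carbonyl carbon alone can move the number by a large amount, beyond the scatter. The step combines the loss of the aromatic ring of 2-(trifluoromethyl)phenyl with the arrival of the hydrogen-bond acceptor of methoxy, so it cannot be assigned to either one, and no measured property of these groups is at hand to bear on it.

Still open, as far as these compounds go, is which part of the change carries the step: an unsubstituted phenyl, an ethoxy or a dimethylamino group on the same carbonyl carbon would begin to separate ring, trifluoromethyl and oxygen. Also open, from the compounds shown here alone, is whether methoxy in place of 2-(trifluoromethyl)phenyl gives a step of similar size when the aryl groups carry bromine, as in compound 2, rather than chlorine.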